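A few compounds are considered here, and "the series" means these few. Any claim that something is new, unique, unknown or untested is made for them only; others in the source may bear on it.

Within the data shown here, compound 2 `COCCC#Cc1c(Cl)c2c(Cl)cc(C(N)=O)nc2n1[C@H]1CCCNC1` gives 86000 nM in a physicochemical assay for solubility, measured as thermodynamic solubility, at pH 7.4 (on this read-out lower numbers stand for lower solubility and higher numbers for higher solubility), the lower of the two numbers measured so far. Among the measured compounds shown here, compound 1 `CC(O)C#Cc1c(Cl)c2c(Cl)cc(C(N)=O)nc2n1[C@H]1CCCNC1` gives 206000 nM, and the only measured step, a 2.4-fold lower number from compound 1 to compound 2 (0.38 log units; beyond the scatter), exchanged the hydroxyl-bearing group for a methoxy-bearing one. Compound 3 `COC(C)(C)CC#Cc1c(Cl)c2c(Cl)cc(C(N)=O)nc2n1[C@H]1CCCNC1` changes (1-methoxy-1-methylethyl in place of methoxymethyl on a saturated chain carbon bound to a triple-bonded carbon). For the measured compounds named here, no measured step matches this change, so the only guide is the modest movement seen from compound 1 to compound 2. Adding two carbons is expected to lower the number moderately. Compound 3 is estimated at 45000 nM, between 15000 nM and 130000 nM. The expected step is a 1.9-fold lower number from compound 2 to compound 3 (0.28 log units; within the scatter).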

Compound 3, solubility: 1200 nM
The estimate for compound 3 lay 38-fold (1.57 log units) above the measured number, outside the stated range (below it).
By their numbers in this assay, from the lowest: compound 3; then compound 2; then compound 1.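

In this assay, 1-methoxy-1-methylethyl in place of methoxymethyl gives a 72-fold lower number from compound 2 to compound 3 (1.86 log units; beyond the scatter), although both groups have no ring and no net charge, so at this position a change that leaves those features the same can still move the number far. Where the chain with the hydroxyl group is replaced, the gap widens to a 170-fold lower number from compound 1 to compound 3 (2.23 log units; beyond the scatter). Nothing available here accounts for the size of these steps. Going by these compounds, whether an amine or a longer unbranched chain at this position would give a similar number remains open.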